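A few compounds are considered here, and "the series" means these few. Any claim that something is new, unique, unknown or untested is made for them only; others in the source may bear on it.

Compound 1 `COc1cc(C(O)(C(F)(F)F)C(F)(F)F)cnc1N1CCN(S(=O)(=O)c2ccc(N)nc2)CC1`, compound 2 `Nc1ccc(S(=O)(=O)N2CCN(c3ncc(C(O)(C(F)(F)F)C(F)(F)F)cc3C#CC3CC3)CC2)cn1` and compound 3 `CC(C)(C)n1cc(-c2cc(C(O)(C(F)(F)F)C(F)(F)F)cnc2N2CCN(S(=O)(=O)c3ccc(N)nc3)CC2)cn1` have been measured; compound 4 `Cc1csc(-c2cc(C(O)(C(F)(F)F)C(F)(F)F)cnc2N2CCN(S(=O)(=O)c3ccc(N)nc3)CC2)c1` has not.

In an ADME assay (liver) for metabolic stability, with Liver microsome (Rattus norvegicus) as the target, using microsomes and NADPH, with a stated time of 30 min, tested at 1 uM (a higher number here means faster removal of the compound, a lower number slower removal), compound 1 reports only a limit, < 14 mL.min-1.g-1. Compound 2 gives 67 mL.min-1.g-1 and compound 3 gives 459 mL.min-1.g-1. Among the two plain numbers, compound 2 sits lowest; its nearest neighbour is compound 3, with a 6.9-fold higher number from compound 2 to compound 3 (0.84 log units; beyond the scatter). The other steps are an at least 4.7-fold higher number from compound 1 to compound 2 (0.67 log units; beyond the scatter) and an at least 32-fold higher number from compound 1 to compound 3 (1.51 log units; beyond the scatter).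

The move to compound 4 is 4-methylthiophen-2-yl in place of 2-cyclopropylethynyl on an aromatic carbon. Among the compounds with values here, of the measured steps, the one from compound 2 to compound 3 is closest in kind: there too a ring took the place of 2-cyclopropylethynyl on an aromatic carbon, and the number rose by a modest amount. The step from compound 1 to compound 3 also ended at the high number. On that basis compound 4 is expected to sit higher than compound 2, by an amount estimated as a 3.3-fold higher number from compound 2 to compound 4 (0.52 log units; beyond the scatter), in this assay. Compound 4 is therefore estimated at 220 mL.min-1.g-1, within a range from 80 mL.min-1.g-1 to 550 mL.min-1.g-1.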

Compound 4, intrinsic clearance in microsomes: 399 mL.min-1.g-1
The estimate for compound 4 lay 1.8-fold (0.26 log units) below the measured number; the range from low to high includes it.
By their numbers in this assay, from the lowest: compound 2; then compounds 4 and 3 (each within the scatter of the next). At a limit, below all of these: compound 1.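

With 4-methylthiophen-2-yl in place of 2-cyclopropylethynyl, this assay shows a 6.0-fold higher number from compound 2 to compound 4 (0.77 log units; beyond the scatter) and so a second aromatic ring at this position, after the 1-(tert-butyl)-1H-pyrazol-4-yl of compound 3, also ends above compound 2. Exchanging one ring for the other gives a 1.2-fold lower number from compound 3 to compound 4 (0.06 log units; within the scatter) and so the two cannot be told apart here, although the rings and the groups they carry differ. Compound 1 stands at a limit, so an at least 28-fold higher number from compound 1 to compound 4 (1.45 log units; beyond the scatter) gives a bound and not a measured size: the limit of < 14 mL.min-1.g-1 in this assay, at which 1 of the 4 values shown sits.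

As far as these compounds go, whether a morpholine or a plain amine at this position would stay near compound 1 or rise with the rings remains open. So does whether a thiophene without its methyl group would read any differently.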